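Swapping Benzyloxy for Isobutoxy on a Carbamate Pyrazole

The source may report more compounds than this note shows. Statements on the series, on what has been measured and on what is new or still open speak of the compounds shown alone.

The series rests on a shared core carrying a chloro-substituted benzyl group on a methylpyrazole that bears an acylated amine. Compound 1 `Cc1cc(NC(=O)C2CCCC2)nn1Cc1cc(Cl)ccc1OCc1ccccc1` has a cyclopentylcarbonyl amide and a benzyloxy ether; in a physicochemical assay for lipophilicity, at pH 7.4 (a lower number here means a more polar compound, a higher number a more lipophilic compound), compound 1 gives 3.5. Compound 2 `Cc1cc(NC(=O)C2CCCC2)nn1Cc1cc(Cl)ccc1OCC(C)C` differs by isopropyl in place of phenyl on a saturated chain carbon bound to an oxygen on an aromatic ring. In this assay compound 2 reaches only a limit, > 3.7. Compound 3 `Cc1cc(NC(=O)OC(C)(C)C)nn1Cc1cc(Cl)ccc1OCc1ccccc1` differs from compound 1 by tert-butoxy in place of cyclopentyl on a carbonyl carbon, and in this assay compound 3 likewise reaches only a limit, > 3.7. Both limits are the same one, (the limit of > 3.7 in this assay, at which 2 of the 3 values shown sit).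

The change from the benzyloxy to the isobutoxy ether has been measured once, from compound 1 to compound 2, where this assay shows a number at least 0.20 log units higher from compound 1 to compound 2 (that floor lies within the scatter). The change of core, from compound 1 to compound 3, shows a number at least 0.20 log units higher from compound 1 to compound 3 (that floor lies within the scatter) in this assay.

Compound 4 `Cc1cc(NC(=O)OC(C)(C)C)nn1Cc1cc(Cl)ccc1OCC(C)C` is not yet measured. It differs from compound 3 by isopropyl in place of phenyl on a saturated chain carbon bound to an oxygen on an aromatic ring, the same change, at the same place, that turns compound 1 into compound 2. Since compound 3 already sits at the limit > 3.7, and the earlier step of a number at least 0.20 log units higher from compound 1 to compound 2 (that floor lies within the scatter) pointed upward, the step for compound 4 is expected to be a step that the limit leaves unreadable from compound 3 to compound 4 in this assay, most likely again reported only as a limit. Compound 4 is therefore estimated at 4.1 in this assay, within 3.7 to 4.6.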

Compound 4, distribution coefficient: > 3.7
Compound 4 gave a limit, no number (the forecaster's own chance of this, stated with the estimate: 85%); the middle value lies beyond the limit too.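

In this assay compound 4 gives > 3.7, which is a limit and not a number. The steps to compound 4 from compound 2 and from compound 3 therefore cannot be read: the limit of > 3.7 in this assay, at which 3 of the 4 values shown sit.

The compounds shown leave open how compound 2, compound 3 and compound 4 rank against one another in this assay, and whether isopropyl in place of phenyl has the same size of effect on both carbonyl groups.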